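Moving the Methyl Group on a Series Held at the Limit

The compounds below may be only part of what the source reports. "The series", "measured", "known", "first", "only" and "open" are said of these compounds alone.

In an ADME assay on HBZY-1 cells (Rattus norvegicus) for cytotoxicity, read by MTT assay, with a stated time of 2 h (a lower number here means a stronger inhibitor, a higher number a weaker inhibitor), compound 1 (`COc1ccccc1NC(=O)/C(C#N)=C/c1ccccc1C(F)(F)F`) gives > 200000 nM and this is a limit of the assay, not a number. Compound 2 (`COc1ccccc1NC(=O)/C(C#N)=C/c1cccc([N+](=O)[O-])c1`) gives > 200000 nM and this too is only a limit. Compound 3 (`COc1ccccc1NC(=O)/C(C#N)=C/c1ccccc1C`) stands at > 200000 nM and this is again a limit, so its place is known only by that bound. Taken together, the record shows the limit of > 200000 nM in this assay, at which 3 of the 3 values shown sit, and holds no exact number so far.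

Compound 4 (`COc1ccccc1NC(=O)/C(C#N)=C/c1cccc(C)c1`) has not yet been measured in this assay and differs from compound 3 in one place. It carries 3-methylphenyl in place of 2-methylphenyl on a double-bonded chain carbon bound to a double-bonded chain carbon and the two have the same atoms, joined differently.

For the measured compounds named here, the one measured step that bears on this change is a step that the two limits leave unreadable from compound 1 to compound 3 and it offers no size to carry over. No step beyond the usual scatter, in either direction, is therefore expected in this assay for this change. The expected step is a step that the limit leaves unreadable from compound 3 to compound 4 and it is an estimate resting on limits alone. Compound 4 is expected at 250000 nM with an estimated range from 120000 nM to 500000 nM and it may well turn out to be only a limit too.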

Compound 4, half-maximal inhibitory concentration: > 200000 nM
Compound 4 was reported as a limit (the forecaster's own chance of this, stated with the estimate: 85%); the middle value lies beyond the limit too.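

In this assay compound 4 gives > 200000 nM and this is again a limit, not a number. For the compounds shown here, no step from compound 2 or compound 3 to compound 4 can be read, and the record stands thus: the limit of > 200000 nM in this assay, at which 4 of the 4 values shown sit. The compounds shown leave open whether any change on the shared core would give an exact number in this assay.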